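A few compounds are considered here, and "the series" means these few. Any claim that something is new, unique, unknown or untested is made for them only; others in the source may bear on it.

In an ADME assay on CHO cells (Cricetulus griseus) for cytotoxicity, read by MTT assay (on this read-out lower numbers stand for higher toxicity in this test and higher numbers for lower toxicity in this test), compound 1 (`Fc1ccc(Nc2cc3[nH]c(Nc4ccc(N5CCNCC5)cn4)nc3cn2)cc1C(F)(F)F`) gives 14000 nM, compound 2 (`Fc1ccc(Nc2cc3[nH]c(Nc4ccc(N5CCN(CC6CC6)CC5)cn4)nc3cn2)cc1C(F)(F)F`) gives 41000 nM, and compound 3 (`Fc1ccc(Nc2cc3[nH]c(Nc4ccc(N5CCNCC5)cn4)nc3cn2)cc1F`) gives 33000 nM. Compound 3 therefore lies within the scatter of compound 2 and clearly apart from compound 1. Compound 4 (`Fc1ccc(Nc2cc3[nH]c(Nc4ccc(C5CCNCC5)cn4)nc3cn2)cc1F`) has piperidin-4-yl in place of piperazin-1-yl on an aromatic carbon. For the measured compounds named here, no measured step makes this exchange. The closest guides are two modest steps made elsewhere: a 2.9-fold higher number from compound 1 to compound 2 (0.47 log units; beyond the scatter), with cyclopropylmethyl in place of hydrogen on an amine nitrogen in a ring, and a 2.4-fold higher number from compound 1 to compound 3 (0.37 log units; beyond the scatter), with fluoro in place of trifluoromethyl. With so little to go on, no step beyond the scatter is expected in this assay. The estimated step is a 1.2-fold lower number from compound 3 to compound 4 (0.09 log units; within the scatter). For compound 4, the expected value is 27000 nM, with an estimated range of 11000 nM to 60000 nM.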

Compound 4, half-maximal cytotoxic concentration in the CHO assay: 50000 nM
Beside the measured number, compound 4's estimate is 1.9-fold (0.27 log units) below it, and the stated range covers the measured number.
By their numbers in the CHO assay, from the lowest: compound 1; then compounds 3, 2 and 4 (each within the scatter of the next).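

In the CHO assay, piperidin-4-yl in place of piperazin-1-yl at this position gives a 1.5-fold higher number from compound 3 to compound 4 (0.18 log units; within the scatter), so the toxicity read-out does not separate the two rings. In a physicochemical assay for solubility, read by HPLC, using the shake flask method, in phosphate buffer, measured as kinetic solubility, with a stated time of 20 h, at pH 6.5 (on this read-out lower numbers stand for lower solubility and higher numbers for higher solubility), the same change brings a large step up in solubility: the measured solubility of compound 3, < 5000 nM, and of compound 4, 190000 nM, an at least 38-fold higher number (1.57 log units; beyond the scatter) In the physicochemical assay compound 3 gives < 5000 nM, which is a limit of the assay and not a number. In the physicochemical assay compound 4 gives 190000 nM.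

On these data alone, whether the change behaves the same way in a compound carrying trifluoromethyl, such as compound 1, stays open. So does what a morpholine or an open-chain amine at this position would do in either assay.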